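From 4-Formylphenyl to Pentafluorophenyl on a Sulfonyl Sulfur

This account rests on a few compounds, and the source may have more. Where it says the series, first, only, none or still open, it means among the compounds named here.

Compound 1 `COc1ccc(-c2cc(=O)c3c(OC)cc(OC)cc3n2Cc2ccccc2)cc1`: > 17300 nM, a limit
Compound 2 `C=CCNC(=O)n1c(-c2ccc(OC)cc2)cc(=O)c2c(OC)cc(OC)cc21`: > 20000 nM, a limit
Compound 3 `COc1ccc(-c2cc(=O)c3c(OC)cc(OC)cc3n2S(=O)(=O)c2ccc(C=O)cc2)cc1`: > 34400 nM, a limit

In a functional assay on HepG2 cells (Homo sapiens) for antiproliferative activity, with a stated time of 72 h (on this read-out lower numbers stand for an effect already at smaller amounts and higher numbers for an effect only at larger amounts of compound), these three compounds share a core and differ in the group on its aromatic nitrogen, and none of them has yielded a number. Compound 3 stands at > 34400 nM, which is a limit of the assay.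

In compound 4 `COc1ccc(-c2cc(=O)c3c(OC)cc(OC)cc3n2S(=O)(=O)c2c(F)c(F)c(F)c(F)c2F)cc1`, 2,3,4,5,6-pentafluorophenyl takes the place of 4-formylphenyl on a sulfonyl sulfur: 2,3,4,5,6-pentafluorophenyl in place of 4-formylphenyl on a sulfonyl sulfur.

Going by the values given here, three measured steps bear on this change only indirectly: a step that the two limits leave unreadable from compound 1 to compound 2, a step that the two limits leave unreadable from compound 1 to compound 3 and a step that the two limits leave unreadable from compound 2 to compound 3. None of them has a readable size, and none is a change on the sulfonyl sulfur itself. Among the compounds with values here, the only anchor is therefore compound 3 with its limit of > 34400 nM, so no step beyond the usual scatter is expected in this assay, in either direction. The expected step is an at least 1.1-fold lower number from compound 3 to compound 4 (0.05 log units; that floor lies within the scatter). A further limit is the likeliest report, though a number remains possible. Compound 4 is estimated at 30000 nM. The expected range for compound 4 runs from 8000 nM to 80000 nM.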

Compound 4, half-maximal effective concentration: > 34400 nM
Compound 4: a limit, no number (the forecaster's own chance of this, stated with the estimate: 70%); at least 1.1-fold (0.05 log units) between middle value and limit.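

In this assay compound 4 gives > 34400 nM, a limit and not a number, so the step from compound 3 to compound 4 cannot be read. Compound 4 and compound 3 stand at the same limit: the limit of > 34400 nM in this assay, at which 2 of the 4 values shown sit.

The compounds shown leave open whether any group on the aromatic nitrogen of the shared core yields a number in this assay.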